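The source may report more compounds than this note shows. Statements on the series, on what has been measured and on what is new or still open speak of the compounds shown alone.

Measured in a functional assay on MCF7 cells (Homo sapiens) for antiproliferative activity, read by MTT assay, with a stated time of 48 h; a higher number here means a weaker inhibitor, a lower number a stronger inhibitor:
- compound 1 `COC/C1=C/C[C@](C)(CCC=C(C)C)/C=C/[C@@H](OC(=O)C=C(C)C)[C@](C)(OC)/C=C/C1=O` gives 16500 nM
- compound 2 `CC(C)=CCC[C@]1(C)/C=C/[C@@H](OC(=O)C=C(C)C)[C@](C)(O)/C=C/C(=O)/C(CN(C)C)=C\C1` gives 690 nM
- compound 3 `CCN(CC)C/C1=C/C[C@](C)(CCC=C(C)C)/C=C/[C@@H](OC(=O)C=C(C)C)[C@](C)(O)/C=C/C1=O` gives 130 nM

Compound 3 has the lowest number of the three, which makes it the strongest inhibitor here, and its gaps to both others lie beyond the scatter. Compound 4 `CC(C)=CCC[C@]1(C)/C=C/[C@@H](OC(=O)C=C(C)C)[C@](C)(O)/C=C/C(=O)/C(CN=[N+]=[N-])=C\C1` has azido in place of diethylamino on a saturated chain carbon bound to a double-bonded ring carbon.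

Among the compounds with values here, only one measured step changes this group: a 5.3-fold lower number from compound 2 to compound 3 (0.72 log units; beyond the scatter). That step shows the group can move the number, but it swaps one amino group for another, so it cannot set the size of a change to azido. Within the data shown here, compound 1, the only measured compound without an amino group, gives 16500 nM, but no single-change step links it to compound 3. A higher number, meaning a weaker inhibitor, is therefore expected, probably by more than that one measured step. The expected change is a 19-fold higher number from compound 3 to compound 4 (1.28 log units; beyond the scatter). For compound 4, the estimated value is 2500 nM, within a range of 400 nM to 15000 nM.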

Compound 4, half-maximal inhibitory concentration: 4890 nM
The estimate for compound 4 lay 2.0-fold (0.29 log units) below the measured number; the measured number falls inside the stated range.
By their numbers in this assay, from the lowest: compound 3; then compound 2; then compound 4; then compound 1.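

In this assay, this position on a saturated chain carbon bound to a double-bonded ring carbon proves sensitive to more than the size of the amino group: azido in place of diethylamino gives a 38-fold higher number from compound 3 to compound 4 (1.58 log units; beyond the scatter), and azido in place of dimethylamino gives a 7.1-fold higher number from compound 2 to compound 4 (0.85 log units; beyond the scatter). Both steps run the same way, so across these three compounds, either amino group gives a lower number than azido, and the choice of group here decides much of the activity of the shared core. Nothing measured here accounts for these steps.

Still open, going by these compounds, is whether a ring amine such as piperidine or morpholine, or a primary amine, would carry this trend further. A longer chain on the nitrogen, such as dipropylamino, could show whether the gain seen with diethylamino continues.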